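The source may report more compounds than this note shows. Statements on the series, on what has been measured and on what is new or still open speak of the compounds shown alone.

Measured so far:
- compound 1 `COc1cc2ncnc(Nc3ccc(NC(=O)c4ccccc4I)cc3)c2cc1OC`: 33000 nM
- compound 2 `COc1cc2ncnc(Nc3ccc(NC(=O)c4ccc(I)cc4)cc3)c2cc1OC`: 40000 nM
- compound 3 `COc1cc2ncnc(Nc3ccc(NC(=O)c4cccc(C(F)(F)F)c4)cc3)c2cc1OC`: 83000 nM

All values come from a functional assay on HepG2 cells (Homo sapiens) for inhibition, read by MTT assay; on this read-out lower numbers stand for stronger inhibition and higher numbers for weaker inhibition. Compound 3 gives the highest of the three numbers, with compound 2 nearest and compound 1 furthest.

The next compound is compound 4 `COc1cc2ncnc(Nc3ccc(NC(=O)c4ccc(C(F)(F)F)cc4)cc3)c2cc1OC`, not yet measured. It differs from compound 3 as follows: 4-(trifluoromethyl)phenyl in place of 3-(trifluoromethyl)phenyl on a carbonyl carbon. In words, 4-(trifluoromethyl)phenyl stands in place of 3-(trifluoromethyl)phenyl on a carbonyl carbon.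

Within the data shown here, no measured pair isolates this exact change. The closest measured step is the iodophenyl pair, a 1.2-fold higher number from compound 1 to compound 2 (0.08 log units; within the scatter), in which the same iodo group changes place. The other two steps change the group as well as its place and are modest: a 2.5-fold higher number from compound 1 to compound 3 (0.40 log units; beyond the scatter) and a 2.1-fold higher number from compound 2 to compound 3 (0.32 log units; beyond the scatter). Among the measured compounds shown here, with only one such pair, the precedent is thin, but it points to little or no change in this assay.

Compound 2, which carries 4-iodophenyl, gives 40000 nM, and this tilts the expectation slightly towards a lower number. The expected change is small and no larger than the scatter: a 1.3-fold lower number from compound 3 to compound 4 (0.11 log units; within the scatter).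

For compound 4 the estimated value is 65000 nM, with an expected range of 30000 nM to 130000 nM.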

Compound 4, half-maximal inhibitory concentration: > 100000 nM
Compound 4 gave a limit, no number; the forecaster's own chance of this, stated with the estimate: 10%; middle value at least 1.5-fold (0.18 log units) from the limit.
By their numbers in this assay, from the lowest: compounds 1 and 2 (each within the scatter of the next); then compound 3. At a limit, above all of these: compound 4.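

Compound 4 reaches the limit of the read-out in this assay, so it gives a limit and not a number: the limit of > 100000 nM in this assay, at which 1 of the 4 values shown sits. Moving the trifluoromethyl group, with 4-(trifluoromethyl)phenyl in place of 3-(trifluoromethyl)phenyl on a carbonyl carbon, gives an at least 1.2-fold higher number from compound 3 to compound 4 (0.08 log units; that floor lies within the scatter), so this change has a floor but no size, and it may be as small as the iodophenyl step a 1.2-fold higher number from compound 1 to compound 2 (0.08 log units; within the scatter) or much larger. Trifluoromethyl in place of iodo on an aromatic carbon is the first step that changes the group without moving it, and it gives an at least 2.5-fold higher number from compound 2 to compound 4 (0.39 log units; beyond the scatter), while the 2-iodophenyl comparison gives an at least 3.0-fold higher number from compound 1 to compound 4 (0.48 log units; beyond the scatter).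

On these data alone, the true value of compound 4 remains open, and with it whether the two trifluoromethylphenyl isomers really differ in this assay. Also open, as far as these compounds go, is how 2-(trifluoromethyl)phenyl, or a phenyl carrying an amine, a carboxylic acid or a nitrile on the carbonyl carbon, would read against these four compounds.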